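Replacing a Large Ring Substituent with a Methoxy Group

A few compounds are considered here, and "the series" means these few. Any claim that something is new, unique, unknown or untested is made for them only; others in the source may bear on it.

Compound 1 `C=CC(=O)Nc1cccc(-n2cnc3cnc(Nc4ccc(N5CCN(C(C)=O)C(C)C5)cc4)nc32)c1` was tested in a functional assay on Ramos cells (Homo sapiens) for antiproliferative activity, read by CCK-8 assay, with a stated time of 48 h; on this read-out higher numbers stand for weaker inhibition and lower numbers for stronger inhibition. In this assay compound 1 gives only a limit, > 40000 nM, rather than a number, so its true value is not known. Two neighbours carry different groups at the same place. Compound 3 `C=CC(=O)Nc1cccc(-n2cnc3cnc(Nc4ccc(N5CCN(C)CC5)cc4)nc32)c1` gives 8220 nM in this assay, and the change is an at least 4.8-fold lower number from compound 1 to compound 3 (0.68 log units; beyond the scatter). Compound 2 `C=CC(=O)Nc1cccc(-n2cnc3cnc(Nc4ccc(N5CCN(S(C)(=O)=O)CC5)cc4OC)nc32)c1` carries a further group elsewhere and gives 38600 nM in this assay. All three numbers sit at the weak end of the scale.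

Compound 4 `C=CC(=O)Nc1cccc(-n2cnc3cnc(Nc4ccc(OC)cc4)nc32)c1` has not yet been measured. It differs from compound 1 in this way: methoxy in place of 4-acetyl-3-methylpiperazin-1-yl on an aromatic carbon. For the measured compounds named here, only the step from compound 1 to compound 3 bears on this change, since it also removes the 4-acetyl-3-methylpiperazin-1-yl group, and it was at least modest in size; yet that step brings in a different group, so carrying it over to a methoxy is uncertain. Because compound 1 sits at the limit of > 40000 nM in this assay, at which 1 of the 3 values shown sits, any step measured from it can only be stated as a lower bound. The expected outcome is a small to modest gain at best, so compound 4 is estimated at 30000 nM, with a range from 8000 nM to 80000 nM, which means an expected step of an at least 1.3-fold lower number from compound 1 to compound 4 (0.12 log units; that floor lies within the scatter).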

Compound 4, half-maximal inhibitory concentration: > 40000 nM
Compound 4: a limit, no number; the forecaster's own chance of this, stated with the estimate: 35%; at least 1.3-fold (0.12 log units) between middle value and limit.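

Compound 4 and compound 1 both stand at a limit of this assay, not at a number, so the step between them cannot be read, because the two share the same ceiling: the limit of > 40000 nM in this assay, at which 2 of the 4 values shown sit.

The step that can be read is an at least 4.8-fold higher number from compound 3 to compound 4 (0.68 log units; beyond the scatter), which shows that a much smaller group at this place, on an aromatic carbon para to a large group, brings no gain over the 4-methylpiperazin-1-yl group. Of the three compounds that differ only here, compound 1, compound 3 and compound 4, only compound 3 gives a number, so taking out the ring and leaving just methoxy does not carry the compound past the limit.

On these data alone, it remains open whether the gain seen in compound 3 rests on the whole piperazine ring or on the methyl on its nitrogen, and a plain piperazin-1-yl, a morpholine ring or a short chain ending in a dimethylamine at this place would help separate the two. As far as these compounds go, it is also open whether any such group can go well past compound 3, which at 8220 nM still sits at the weak end of the scale.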